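Dropping a methyl from compound 1: an estimate for compound 3

The source may hold more compounds than are shown below. What is called first, only, known or untested is meant among the compounds shown, and "the series" means these compounds.

Measured compounds:
compound 1, `Cc1ccc2oc(-c3ccc(NC(=O)CN4CCN(CCCN(C)C)CC4)cc3)nc2c1`, 1810 nM
compound 2, `Cc1ccc2oc(-c3ccc(NC(=O)CN4CCN(CCCN(C)C)CC4)c(C)c3)nc2c1`, 7320 nM

Of the compounds shown here, two have been measured in a functional assay on C6 cells (Rattus norvegicus) for cytotoxicity, read by MTT assay, with a stated time of 24 h; on this read-out lower numbers stand for stronger inhibition and higher numbers for weaker inhibition. Compound 1 gives 1810 nM, the lowest of the two numbers. Among the compounds with values here, its nearest neighbour, compound 2, gives 7320 nM; the only measured step, a 4.0-fold higher number from compound 1 to compound 2 (0.61 log units; beyond the scatter), is a methyl in place of hydrogen on an aromatic carbon of the central ring.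

Compound 3, `CN(C)CCCN1CCN(CC(=O)Nc2ccc(-c3nc4ccccc4o3)cc2)CC1`, has not yet been measured. It differs from compound 1 by hydrogen in place of methyl on an aromatic carbon, a change that reads as 5-methyl-1,3-benzoxazol-2-yl to 1,3-benzoxazol-2-yl. Within the data shown here, no measured step touches this position: the step from compound 1 to compound 2 concerns a methyl on a different ring, so it shows only that a methyl elsewhere can move the number modestly, and it does not say in which direction the loss of this methyl will go. The expectation for compound 3 is therefore a step of a 1.1-fold higher number from compound 1 to compound 3 (0.04 log units; within the scatter), that is, no change beyond the scatter, with a wide allowance either way. Compound 3 is estimated at 2000 nM, within 800 nM to 5000 nM.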

Compound 3, half-maximal inhibitory concentration: 42300 nM
Compound 3: the middle estimate sits 21-fold (1.33 log units) below what was measured; the measured number lies above the stated range.
By their numbers in this assay, from the lowest: compound 1; then compound 2; then compound 3.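

In this assay, within the data shown here, the methyl of the 5-methyl-1,3-benzoxazol-2-yl group proves to matter far more than the earlier compounds could show: hydrogen in its place gives a 23-fold higher number from compound 1 to compound 3 (1.37 log units; beyond the scatter) and is a large step, although only one heavy atom, a single carbon, leaves. The two methyl changes also point the same way on the read-out from opposite edits, since adding a methyl on the central ring gives a 4.0-fold higher number from compound 1 to compound 2 (0.61 log units; beyond the scatter) while removing this one raises the number much further, so among these three compounds a methyl has no single effect and its outcome depends on the ring that carries it. Nothing available here explains why this position responds so strongly.

From the compounds shown here alone, it remains open whether another group on this same carbon, such as an ethyl, a methoxy or a chlorine, would keep the number of compound 1, match it or take it lower. The compounds shown also do not tell whether hydrogen in place of this methyl would move the number as far in compound 2, which carries the second methyl on the central ring.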